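Three esters, one shared core, a fourth to estimate

This account rests on a few compounds, and the source may have more. Where it says the series, first, only, none or still open, it means among the compounds named here.

Compound 1 `COC(=O)[C@H](NC(=O)Cn1cc(C2=C(c3c[nH]c4ccccc34)C(=O)N(C)C2=O)c2ccccc21)[C@@H](C)O`: 21400 nM
Compound 2 `COC(=O)[C@@H](C)NC(=O)Cn1cc(C2=C(c3c[nH]c4ccccc34)C(=O)N(C)C2=O)c2ccccc21`: 15800 nM
Compound 3 `COC(=O)[C@@H](CO)NC(=O)Cn1cc(C2=C(c3c[nH]c4ccccc34)C(=O)N(C)C2=O)c2ccccc21`: 23200 nM

Three compounds share one core and differ only in the side chain carried on the amide nitrogen. In a functional assay on A2780 cells (Homo sapiens) for cytotoxicity, read by MTT assay, with a stated time of 24 h (on this read-out higher numbers stand for weaker inhibition and lower numbers for stronger inhibition), compound 1 gives 21400 nM, compound 2 gives 15800 nM and compound 3 gives 23200 nM. The three numbers sit close together: a 1.4-fold lower number from compound 1 to compound 2 (0.13 log units; within the scatter), a 1.1-fold higher number from compound 1 to compound 3 (0.04 log units; within the scatter), a 1.5-fold higher number from compound 2 to compound 3 (0.17 log units; within the scatter). Compound 3 has the highest of the three numbers, but its gaps to compound 1 and to compound 2 both lie within the scatter, so no ranking can be read from them.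

Compound 4 `COC(=O)CC[C@@H](NC(=O)Cn1cc(C2=C(c3c[nH]c4ccccc34)C(=O)N(C)C2=O)c2ccccc21)C(=O)OC` has not yet been measured in this assay. It differs from compound 3 in one place: (methoxycarbonyl)methyl in place of hydroxy on a saturated chain carbon, two bonds along the chain from an amide-type nitrogen and a carbonyl carbon. Within the data shown here, none of the measured steps swaps exactly this pair of groups. The nearest is a 1.5-fold higher number from compound 2 to compound 3 (0.17 log units; within the scatter), in which a hydroxy group entered at the same place without moving the number beyond the scatter; the two other side-chain changes also stayed within the scatter. The side chain has so far barely moved the numbers, so compound 4 is expected to land within the scatter of compound 3: a 1.2-fold lower number from compound 3 to compound 4 (0.06 log units; within the scatter). The estimate for compound 4 is 20000 nM, with a range from 8000 nM to 50000 nM.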

Compound 4, half-maximal inhibitory concentration: 32300 nM
Compound 4: the middle estimate sits 1.6-fold (0.21 log units) below what was measured; the range from low to high includes it.
By their numbers in this assay, from the lowest: compounds 2, 1, 3 and 4 (each within the scatter of the next, the first and the last beyond it).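

In this assay this position now gives its first step beyond the scatter, though a modest one: with (methoxycarbonyl)methyl in place of hydrogen there is a 2.0-fold higher number from compound 2 to compound 4 (0.31 log units; beyond the scatter) on the side chain. The same group in place of hydroxy gives a 1.4-fold higher number from compound 3 to compound 4 (0.14 log units; within the scatter) and stays within the scatter. Likewise, 2-(methoxycarbonyl)ethyl in place of 1-hydroxyethyl gives a 1.5-fold higher number from compound 1 to compound 4 (0.18 log units; within the scatter) and also stays within the scatter, so only the comparison with compound 2 separates compound 4 from the other esters.

Still open, on these data alone, is whether a carboxylic acid in place of the methyl ester, an amine, or a longer chain at this place would move the number further. The compounds shown come with no measurement that explains the one step beyond the scatter.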